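Working notes: methoxy placement and an estimate for compound 4

The source may report more compounds than this note shows. Statements on the series, on what has been measured and on what is new or still open speak of the compounds shown alone.

Measured compounds:
compound 1, `COc1cccc(OC/C=C(\C)CC/C=C(\C)C2CC(=O)C(C)(C)O2)c1`, gives 51.5 ug/mL in a functional assay on MT4 cells (Homo sapiens) for inhibition; on this read-out lower numbers stand for stronger inhibition and higher numbers for weaker inhibition
compound 2, `C/C(=C\COc1ccccc1)CC/C=C(\C)C1CC(=O)C(C)(C)O1`, gives 43.1 ug/mL in this assay
compound 3, `C/C(=C\COc1ccccc1)CC/C=C(\C)C1=CC(=O)C(C)(C)O1`, gives 29.4 ug/mL in this assay

Compound 2 and compound 3 carry the same chain and the same unsubstituted phenyl and differ only in the core: a group of 8 heavy atoms (6 carbon, 2 oxygen; one five-membered non-aromatic ring with 1 hetero atom) in place of a group of 8 heavy atoms (6 carbon, 2 oxygen; one five-membered non-aromatic ring with 1 hetero atom), on a double-bonded chain carbon bound to a double-bonded chain carbon and a saturated chain carbon. That exchange gives a 1.5-fold lower number from compound 2 to compound 3 (0.17 log units; within the scatter), so the two cores cannot be told apart on these numbers.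

Compound 1 is compound 2 with a methoxy added on the ring: methoxy in place of hydrogen on an aromatic carbon. This gives a 1.2-fold higher number from compound 2 to compound 1 (0.08 log units; within the scatter), again within the scatter; all three measured numbers lie within the scatter of one another, and no order among them is claimed.

Compound 4, `COc1ccc(OC/C=C(\C)CC/C=C(\C)C2=CC(=O)C(C)(C)O2)cc1`, is not yet measured. It is compound 3 with a methoxy added on the ring: methoxy in place of hydrogen on an aromatic carbon. The place lines are not identical: in compound 1 the methoxy is meta to a large group, in compound 4 it is para to a large group, so the change is of the same kind, not the same.

The step from compound 3 to compound 4 is expected to be a 1.1-fold higher number from compound 3 to compound 4 (0.05 log units; within the scatter) in this assay, close to the earlier one, because a 1.2-fold higher number from compound 2 to compound 1 (0.08 log units; within the scatter) stayed within the scatter and nothing here separates the two rings on this read-out. Compound 4 is therefore estimated at 33 ug/mL, with a range from 15 ug/mL to 70 ug/mL.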

Compound 4, half-maximal inhibitory concentration: 33.9 ug/mL
For compound 4 the middle estimate is 1.0-fold (0.01 log units) below the measured one, and the stated range covers the measured number.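

In this assay, methoxy in place of hydrogen on an aromatic carbon gives a 1.2-fold higher number from compound 3 to compound 4 (0.06 log units; within the scatter) on one core and a 1.2-fold higher number from compound 2 to compound 1 (0.08 log units; within the scatter) on the other. Set side by side, the two steps do not differ: the same change on two cores in this assay, a 1.2-fold higher number (0.08 log units; within the scatter) from compound 2 to compound 1 and a 1.2-fold higher number (0.06 log units; within the scatter) from compound 3 to compound 4, 1.0-fold (0.02 log units) apart, within the scatter of two such steps. This shows that, across these two cores, the change leaves no mark that can be told from the scatter, but with both steps inside the scatter there is no measurable effect to carry over, so it does not show that a real effect of the methoxy would transfer from one core to the other, and the two pairs are also not strictly the same change, since the methoxy does not stand at the same place on the ring in compound 1 as in compound 4, where it is para to a large group.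

Open, on these data alone, is whether a group other than methoxy on the aromatic ring, such as an amine, a carboxylic acid or a halogen like chlorine, would give a step beyond the scatter on either core. Also open, as far as these compounds go, is what a change to the chain itself, such as a longer or a fully saturated chain, would do to the number in this assay.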